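This account rests on a few compounds, and the source may have more. Where it says the series, first, only, none or still open, it means among the compounds named here.

Measured so far in a functional assay on the whole organism for inhibition, with Mus musculus as the target; a higher number here means that more compound is needed for the effect, a lower number that less compound is needed:
- compound 1 `CCN1CCCC1CNC(=O)c1cc(NS(C)(=O)=O)c(C)cc1OC`: 35.6 mg/kg
- compound 2 `CCN1CCCC1CNC(=O)c1cc(N(C)S(N)(=O)=O)ccc1OC`: > 50 mg/kg

In this assay compound 1 gives 35.6 mg/kg. For compound 2 the read-out is a limit and not a number, > 50 mg/kg. Compound 2 thus sits at the limit of > 50 mg/kg in this assay, at which 1 of the 2 values shown sits. Compound 1 and compound 2 differ in two places, so their two values say nothing about either change on its own.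

Compound 3 `CCN1CCCC1CNC(=O)c1cc(N(C)S(N)(=O)=O)c(C)cc1OC` is the next member to be measured. It differs from compound 2 by methyl in place of hydrogen on an aromatic carbon. For the measured compounds named here, no measured pair covers this change alone. The expected step is a step that the limit leaves unreadable from compound 2 to compound 3, modest in size and of uncertain direction, with a real chance that only a limit is reported again. For compound 3 the estimate in this assay is 60 mg/kg, with a range from 25 mg/kg to 150 mg/kg.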

Compound 3, dose for half-maximal effect: > 50 mg/kg
Compound 3 gave a limit, no number; the forecaster's own chance of this, stated with the estimate: 55%; the middle value is on the limit's open side.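

With methyl in place of hydrogen on an aromatic carbon, ortho to the methyl(sulfamoyl)amino group, the compound stays at the limit of this assay, so the methyl does not bring a number into view and the step between compound 2 and compound 3 cannot be read: the limit of > 50 mg/kg in this assay, at which 2 of the 3 values shown sit.

For the compounds shown here, compound 1 and compound 3 now form the first pair that differs in one place, with methyl(sulfamoyl)amino in place of methanesulfonamido on an aromatic carbon, and this assay gives an at least 1.4-fold higher number from compound 1 to compound 3 (0.14 log units; that floor lies within the scatter). That floor alone does not separate the two groups.

From the compounds shown here alone, the size of both steps stays open, as does any effect of the methyl on this carbon. Also open, going by these compounds, is how a chloro or ethyl group on this aromatic carbon, or a primary amine in place of methyl(sulfamoyl)amino, would read.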